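Aryl change from compound 2 to compound 3

This account rests on a few compounds, and the source may have more. Where it says the series, first, only, none or still open, it means among the compounds named here.

Compound 1 `COc1cc(-c2ccnc3cc(-c4ccc(F)cc4)nn23)cc(OC)c1OC`: 5030 nM
Compound 2 `COc1cc(-c2ccnc3cc(-c4ccc(N(C)C)cc4)nn23)cc(OC)c1OC`: 2050 nM

In a functional assay on HCT-116 cells (Homo sapiens) for inhibition, read by CCK-8 assay, with a stated time of 48 h (on this read-out lower numbers stand for stronger inhibition and higher numbers for weaker inhibition), compound 2 holds the lower of the two numbers, at 2050 nM. Compound 3 `COc1cc(-c2ccnc3cc(-c4ccc5ccn(C)c5c4)nn23)cc(OC)c1OC` differs from compound 2 by one change: 1-methyl-1H-indol-6-yl in place of 4-(dimethylamino)phenyl on an aromatic carbon. Going by the values given here, the only measured step, a 2.5-fold lower number from compound 1 to compound 2 (0.39 log units; beyond the scatter), is modest and altered a substituent on this same aryl group. It offers thin guidance for swapping the whole group. A further drop is nevertheless expected, probably larger than that step, with wide uncertainty. The expected move is a 5.1-fold lower number from compound 2 to compound 3 (0.71 log units; beyond the scatter). For compound 3 the estimate is 400 nM, with an expected range of 40 nM to 3000 nM.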

Compound 3, half-maximal inhibitory concentration: 1040 nM
The estimate for compound 3 lay 2.6-fold (0.41 log units) below the measured number; measured number inside the range.
By their numbers in this assay, from the lowest: compounds 3 and 2 (each within the scatter of the next); then compound 1.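

In this assay, 1-methyl-1H-indol-6-yl in place of 4-(dimethylamino)phenyl gives a 2.0-fold lower number from compound 2 to compound 3 (0.29 log units; within the scatter), so these two groups cannot be told apart at this position. Set against 4-fluorophenyl, the same group gives a 4.8-fold lower number from compound 1 to compound 3 (0.68 log units; beyond the scatter), so a second aromatic ring on this carbon keeps the advantage over compound 1 already seen with compound 2. No evidence is available to explain these differences.

From the compounds shown here alone, whether a morpholine or a carboxylic acid on this aryl group would shift the number further remains open. The effect of replacing the methoxy groups on the shared core is also unresolved.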